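The source may report more compounds than this note shows. Statements on the series, on what has been measured and on what is new or still open speak of the compounds shown alone.

Two analogues of the shared core have numbers in an assay on cells for inhibition of Voltage-dependent T-type calcium channel subunit alpha-1I (Homo sapiens), read by patch clamp (a lower number here means a stronger inhibitor, a higher number a weaker inhibitor), so far. Compound 1 `O=C(CC1c2ccccc2N=C(SCCCCCN2CCCC2)N1c1ccc(-c2ccc(F)cc2)cc1)NCc1ccccc1` gives 5100 nM in this assay. Compound 2 `CN(C)CCCCCSC1=Nc2ccccc2C(CC(=O)NCc2ccccc2)N1c1ccccc1` gives 3200 nM in this assay; the two values lie within the scatter of each other, so no order between them is read. Compound 3 `O=C(CC1c2ccccc2N=C(SCCCCCN2CCCC2)N1c1ccccc1)NCc1ccccc1` is not yet measured. It differs from compound 2 by pyrrolidin-1-yl in place of dimethylamino on a saturated chain carbon, five bonds along the chain from a sulfur. Within the data shown here, no measured step of this kind exists, so the expectation rests on the change alone: a step from compound 2 to compound 3 of a 1.1-fold lower number from compound 2 to compound 3 (0.03 log units; within the scatter) is expected, in no particular direction beyond the scatter. For compound 3 the expected value in this assay is 3000 nM, within 1200 nM to 8000 nM.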

Compound 3, half-maximal inhibitory concentration: 6190 nM
Beside the measured number, compound 3's estimate is 2.1-fold (0.31 log units) below it; measured number inside the range.
By their numbers in this assay, from the lowest: compounds 2, 1 and 3 (each within the scatter of the next).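

In this assay, pyrrolidin-1-yl in place of dimethylamino on a saturated chain carbon, five bonds along the chain from a sulfur, gives a 1.9-fold higher number from compound 2 to compound 3 (0.29 log units; within the scatter) and so does not separate the two amines. Hydrogen in place of 4-fluorophenyl on an aromatic carbon gives a 1.2-fold higher number from compound 1 to compound 3 (0.08 log units; within the scatter), so that group's presence is likewise not resolved from its absence. No supporting data bear on these results. Open, from the compounds shown here alone, is whether morpholin-4-yl in place of these amines, or a shorter chain to the sulfur, moves the number beyond the scatter.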